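Amine-nitrogen substituent swap in the isoindolinone urotensin series

This account rests on a few compounds, and the source may have more. Where it says the series, first, only, none or still open, it means among the compounds named here.

For the measured compounds named here, compound 2 `CCN1CCN(c2cccc3c2CN([C@H](CCCNC(=O)c2cccs2)c2ccc(OC)c(OC)c2)C3=O)CC1` gives 140 nM in a functional assay on RMS13 cells for antagonist activity at Urotensin-2 receptor (Homo sapiens), read by FLIPR and calcium flux, with a stated time of 1 h (a higher number here means a weaker inhibitor, a lower number a stronger inhibitor), the higher of the two numbers so far; compound 1 `CCN1CCN(c2cccc3c2CN([C@H](CCCNS(=O)(=O)c2c[nH]cn2)c2ccc(OC)c(OC)c2)C3=O)CC1` gives 51 nM. Going by the values given here, the only measured step at this position is a 2.7-fold higher number from compound 1 to compound 2 (0.44 log units; beyond the scatter), which shows that changing the group on this amine nitrogen moves the number modestly. Compound 3 `CCN1CCN(c2cccc3c2CN([C@H](CCCNc2cncc(OC)n2)c2ccc(OC)c(OC)c2)C3=O)CC1` differs from compound 2 by 6-methoxypyrazin-2-yl in place of (thiophen-2-yl)carbonyl on an amine nitrogen. Given the modest size of the step from compound 1 to compound 2 a 2.7-fold higher number from compound 1 to compound 2 (0.44 log units; beyond the scatter), a step of about that size in either direction is expected, with a slight lean toward a lower number. Compound 3 is estimated at 100 nM (range 30 nM to 400 nM), an expected step of a 1.4-fold lower number from compound 2 to compound 3 (0.15 log units; within the scatter).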

Compound 3, half-maximal inhibitory concentration: 62 nM
Beside the measured number, compound 3's estimate is 1.6-fold (0.21 log units) above it; measured number inside the range.
By their numbers in this assay, from the lowest: compounds 1 and 3 (each within the scatter of the next); then compound 2.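

In this assay, the amine nitrogen accepts an aromatic ring carried directly, with neither carbonyl nor sulfonyl in the link: a 2.3-fold lower number from compound 2 to compound 3 (0.35 log units; beyond the scatter). Against the sulfonyl group, a 1.2-fold higher number from compound 1 to compound 3 (0.08 log units; within the scatter), so 6-methoxypyrazin-2-yl and (1H-imidazol-4-yl)sulfonyl cannot be told apart here, and only (thiophen-2-yl)carbonyl stands apart from both. Nothing available gives a reason for these steps.

Still open, from the compounds shown here alone, is what the methoxy contributes, which a pyrazin-2-yl without it would test. Also open, going by these compounds, is how a small acetyl or methanesulfonyl group on this nitrogen would read.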